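Azetidin-3-yl to pyrrolidin-3-yl on the shared core

A few compounds are considered here, and "the series" means these few. Any claim that something is new, unique, unknown or untested is made for them only; others in the source may bear on it.

Measured so far in a functional assay on NCI-H2228 cells (Homo sapiens) for inhibition, read by CellTiter-Glo, with a stated time of 96 h (on this read-out higher numbers stand for weaker inhibition and lower numbers for stronger inhibition), with two compounds
- compound 1 `Cc1cc(Nc2ncc(Cl)c(Nc3cn(C)nc3S(=O)(=O)C(C)C)n2)c(OC(C)C)cc1C1CCN(C)C1` gives 131 nM
- compound 2 `Cc1cc(Nc2ncc(Cl)c(Nc3cn(C)nc3S(=O)(=O)C(C)C)n2)c(OC(C)C)cc1C1CNC1` gives 288 nM

Compound 2 holds the higher of the two numbers, so it is the weaker of the pair. Within the data shown here, the only measured step is a 2.2-fold higher number from compound 1 to compound 2 (0.34 log units; beyond the scatter) and it is modest, though beyond the scatter. Next in line is compound 3 `Cc1cc(Nc2ncc(Cl)c(Nc3cn(C)nc3S(=O)(=O)C(C)C)n2)c(OC(C)C)cc1C1CCNC1` with pyrrolidin-3-yl in place of azetidin-3-yl on an aromatic carbon on an aromatic carbon, ortho to a methyl group and meta to an isopropoxy group.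

That single step bears on the change only in part. Among the measured compounds shown here, it replaces azetidin-3-yl with 1-methylpyrrolidin-3-yl in one move, and no measured pair separates the ring size from the methyl group. Compound 1 at 131 nM is still the closest guide, as it also carries a five-membered non-aromatic ring. The expected change is therefore small and toward a lower number, estimated as a 1.8-fold lower number from compound 2 to compound 3 (0.26 log units; within the scatter) in this assay for now. For compound 3 the estimated value is 160 nM with 65 nM to 380 nM as its expected range.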

Compound 3, half-maximal inhibitory concentration: 364 nM
Compound 3: the middle estimate sits 2.3-fold (0.36 log units) below what was measured; the range from low to high includes it.
By their numbers in this assay, from the lowest: compound 1; then compounds 2 and 3 (each within the scatter of the next).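

In this assay, pyrrolidin-3-yl in place of azetidin-3-yl on the aromatic carbon ortho to the methyl group gives a 1.3-fold higher number from compound 2 to compound 3 (0.10 log units; within the scatter) and stays within the scatter, so this pair does not separate the four-membered ring from the five-membered ring when the ring nitrogen carries hydrogen. The methyl group on the ring nitrogen can now be read apart from ring size: on the five-membered ring, hydrogen in place of methyl gives a 2.8-fold higher number from compound 1 to compound 3 (0.44 log units; beyond the scatter) and this modest step lies beyond the scatter, which makes it the only single-place step among these compounds to do so. No measured property in hand bears on these steps.

The compounds shown leave open whether a methyl group on the ring nitrogen of the azetidine would give a step of similar size to the one seen on the pyrrolidine, so the effect of that methyl group is read on one ring only. Also open, on these data alone, are a six-membered piperidin-4-yl ring at this position and longer groups on the ring nitrogen, such as ethyl or isopropyl.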